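Trimming a butyl to an isopropyl on a shared core

This account rests on a few compounds, and the source may have more. Where it says the series, first, only, none or still open, it means among the compounds named here.

Measured in an in vitro ADME assay on microsomes from liver (Homo sapiens) for metabolic stability, read by LC-MS; a lower number here means that the compound disappears faster, a higher number that the compound lasts longer:
- compound 1, `CCCCc1ccc(NC(=O)N2CCCN(C(=O)CCC3CCCC3)CC2)cc1`: 0.0833 h
- compound 2, `O=C(CCC1CCCC1)N1CCCN(C(=O)Nc2ccccc2)CC1`: 0.05 h

Compound 1 has the larger of the two numbers, but a 1.7-fold lower number from compound 1 to compound 2 (0.22 log units; within the scatter) lies within the scatter, so the two compounds are not separated by this assay. Compound 3, `CC(C)c1ccc(NC(=O)N2CCCN(C(=O)CCC3CCCC3)CC2)cc1`, has not been measured. It differs from compound 1 by isopropyl in place of butyl on an aromatic carbon. Going by the values given here, only one measured step bears on this change, a 1.7-fold lower number from compound 1 to compound 2 (0.22 log units; within the scatter), in which the butyl is removed entirely at the same place, and even that left the number within the scatter. Keeping a group there rather than removing it gives no reason to expect anything different, so in this assay no step beyond the scatter is expected in either direction. The estimated step is a 1.0-fold lower number from compound 1 to compound 3 (0.02 log units; within the scatter). For compound 3 the expected value is 0.08 h, with a range from 0.04 h to 0.17 h.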

Compound 3, half-life: 0.117 h
Compound 3: middle estimate off by 1.5-fold (0.17 log units), on the low side, and the stated range covers the measured number.
By their numbers in this assay, from the lowest: compounds 2, 1 and 3 (each within the scatter of the next, the first and the last beyond it).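

In this assay this place on the aromatic ring now gives its first step beyond the usual scatter, a modest one, when isopropyl stands in place of hydrogen (a 2.3-fold higher number from compound 2 to compound 3 (0.37 log units; beyond the scatter)). The change from butyl to isopropyl does not separate the two compounds (a 1.4-fold higher number from compound 1 to compound 3 (0.15 log units; within the scatter)), so a group at this place can matter while these two groups remain indistinguishable here. Nothing measured in these compounds explains the difference between hydrogen and isopropyl.

The compounds shown leave open whether a methyl, a tert-butyl, a methoxy or an amine at this same place would give a similar number or a clearly different one. They also leave open whether the isopropyl step would hold if the cyclopentyl end of the shared core were replaced by another group.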